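Exposure notes: second fluoro on the pendant phenyl

The compounds below may be only part of what the source reports. "The series", "measured", "known", "first", "only" and "open" are said of these compounds alone.

Compound 1 `O=C(Nc1ccc(F)c(-c2nc3ncc(-c4ccccc4F)cc3[nH]2)c1)N1CCCC1`: 2230 nM
Compound 2 `O=C(Nc1ccc(F)c(-c2nc3ncc(-c4ccc(F)cc4)cc3[nH]2)c1)N1CCCC1`: 6270 nM

Among the compounds with values here, in an ADME assay on the whole organism (Mus musculus, strain Swiss Webster) for pharmacokinetics, read by LC-MS, at a dose of 50 mg/kg by the oral route (on this read-out higher numbers stand for higher exposure at the dose given and lower numbers for lower exposure), compound 1 gives 2230 nM, the lowest of the two numbers so far. Compound 2 gives 6270 nM, the step being a 2.8-fold higher number from compound 1 to compound 2 (0.45 log units; beyond the scatter). Compound 3 `O=C(Nc1ccc(F)c(-c2nc3ncc(-c4cccc(F)c4F)cc3[nH]2)c1)N1CCCC1` differs from compound 1 by fluoro in place of hydrogen on an aromatic carbon, ortho to a fluoro group; read one bond further out, 2-fluorophenyl becomes 2,3-difluorophenyl. Within the data shown here, the one measured step moves the fluoro rather than adding a second, so it bears only loosely here. No step beyond the scatter is expected, a 1.1-fold higher number from compound 1 to compound 3 (0.05 log units; within the scatter). Compound 3 is estimated at 2500 nM, with a range of 1000 nM to 6500 nM.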

Compound 3, maximal plasma concentration: 1830 nM
The estimate for compound 3 lay 1.4-fold (0.14 log units) above the measured number; the measured number falls inside the stated range.
By their numbers in this assay, from the lowest: compounds 3 and 1 (each within the scatter of the next); then compound 2.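

In this assay, the second fluoro on 2-fluorophenyl gives no step beyond the scatter (a 1.2-fold lower number from compound 1 to compound 3 (0.09 log units; within the scatter)). The gap to the 4-fluorophenyl of compound 2 remains with 2,3-difluorophenyl (a 3.4-fold lower number from compound 2 to compound 3 (0.53 log units; beyond the scatter)), so among these three, compound 1 and compound 3 sit together and only compound 2 stands apart. Nothing available accounts for this. Open, going by these compounds, is how 3,4-difluorophenyl would read, with a fluoro kept where compound 2 carries it, and how a methoxy group or an amine would read on the same ring.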